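Trading a Nitro Group for Trifluoromethyl: What to Expect

The compounds below may be only part of what the source reports. "The series", "measured", "known", "first", "only" and "open" are said of these compounds alone.

Three measured compounds share one core and differ only in the group on the outer aromatic ring. Compound 1 `COc1cc2ncnc(NCc3cccc(NC(=O)Nc4ccc(F)cc4)c3)c2cc1OC` gives 36600 nM in a functional assay on HepG2 cells (Homo sapiens) for antiproliferative activity, read by MTT assay; on this read-out higher numbers stand for weaker inhibition and lower numbers for stronger inhibition. For compound 2 `COc1cc2ncnc(NCc3cccc(NC(=O)Nc4ccc(Cl)cc4)c3)c2cc1OC` this assay reports only a limit, > 50000 nM. Compound 3 `COc1cc2ncnc(NCc3cccc(NC(=O)Nc4ccc([N+](=O)[O-])cc4)c3)c2cc1OC` gives 18800 nM, which stands lowest of the two numbers shown; the step of a 1.9-fold lower number from compound 1 to compound 3 (0.29 log units; within the scatter) stays within the scatter, whereas an at least 2.6-fold lower number from compound 2 to compound 3 (0.42 log units; beyond the scatter) goes beyond it, and an at least 1.3-fold higher number from compound 1 to compound 2 (0.13 log units; that floor lies within the scatter) adds little. Compound 4 `COc1cc2ncnc(NCc3cccc(NC(=O)Nc4cccc(C(F)(F)F)c4)c3)c2cc1OC` carries 3-(trifluoromethyl)phenyl in place of 4-nitrophenyl on an amide-type nitrogen. For the measured compounds named here, no measured step covers a trifluoromethyl group or this placement; the only comparisons are the fluoro, chloro and nitro swaps just described. Compound 4 is therefore expected to move by a 1.9-fold higher number from compound 3 to compound 4 (0.27 log units; within the scatter). The estimate for compound 4 is 35000 nM, expected between 12000 nM and 100000 nM.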

Compound 4, half-maximal inhibitory concentration: 34200 nM
Beside the measured number, compound 4's estimate is 1.0-fold (0.01 log units) above it; measured number inside the range.
By their numbers in this assay, from the lowest: compounds 3, 4 and 1 (each within the scatter of the next). At a limit, above all of these: compound 2.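

In this assay, 3-(trifluoromethyl)phenyl on the amide-type nitrogen can replace 4-nitrophenyl, with a 1.8-fold higher number from compound 3 to compound 4 (0.26 log units; within the scatter), or 4-fluorophenyl, with a 1.1-fold lower number from compound 1 to compound 4 (0.03 log units; within the scatter), so this new group and placement leave the number within the scatter of both. Compound 2 stands at a limit of the assay: the limit of > 50000 nM in this assay, at which 1 of the 4 values shown sits. Its step therefore gives only a floor, an at least 1.4-fold lower number from compound 2 to compound 4 (0.16 log units; that floor lies within the scatter).

Trifluoromethyl and its placement change together here, so their separate contributions remain unknown. Also open, from the compounds shown here alone, is how an amine or a carboxylic acid on this outer ring would read.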